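The source may hold more compounds than are shown below. What is called first, only, known or untested is meant among the compounds shown, and "the series" means these compounds.

Measured compounds:
compound 1 `CO[C@@H]1[C@@H](OC(=O)c2ccc(C)[nH]2)[C@@H](O)[C@H](Oc2ccc3c(N4CC(C)NC(C)C4)cc(=O)oc3c2C)OC1(C)C` — 8
compound 2 `CO[C@@H]1[C@@H](OC(=O)c2ccc(C)[nH]2)[C@@H](O)[C@H](Oc2ccc3c(N4CCN(C)CC4)cc(=O)oc3c2C)OC1(C)C` — 7.3

In a physicochemical assay for acid dissociation, compound 2 stands lowest of the two numbers; its nearest neighbour is compound 1, and a number 0.70 log units lower from compound 1 to compound 2 (beyond the scatter). Compound 3 `CCN1CCN(c2cc(=O)oc3c(C)c(O[C@@H]4OC(C)(C)[C@H](OC)[C@@H](OC(=O)c5ccc(C)[nH]5)[C@H]4O)ccc23)CC1` is not yet measured. Its change from compound 2 is methyl in place of hydrogen on a saturated chain carbon bound to an amine nitrogen in a ring, read one bond further out as 4-methylpiperazin-1-yl to 4-ethylpiperazin-1-yl. Among the measured compounds shown here, no measured step covers this change; the only step alters the ring substitution pattern rather than the group on the ring nitrogen, so it does not bear on it directly. A step within the scatter is expected, a number 0.10 log units higher from compound 2 to compound 3 (within the scatter). Compound 3 is estimated at 7.4, between 7 and 7.8.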

Compound 3, acid dissociation constant: 7.5
For compound 3 the middle estimate is 0.10 log units below the measured one; low and high end bracket the measured number.
By their numbers in this assay, from the lowest: compounds 2 and 3 (each within the scatter of the next); then compound 1.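

In this assay, 4-ethylpiperazin-1-yl in place of 4-methylpiperazin-1-yl gives a number 0.20 log units higher from compound 2 to compound 3 (within the scatter), so methyl in place of hydrogen at this position leaves compound 3 within the scatter of compound 2. Against 3,5-dimethylpiperazin-1-yl, the same ethyl group gives a number 0.50 log units lower from compound 1 to compound 3 (beyond the scatter), a step beyond the scatter, as with methyl. No evidence on hand accounts for either step.

Still open, on these data alone, is whether a longer chain such as propyl stays within the scatter at this position. A hydroxyethyl group or a carboxylic acid at the chain end is equally unresolved.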